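The compounds below may be only part of what the source reports. "The series", "measured", "known", "first", "only" and "open" are said of these compounds alone.

Among the compounds with values here, in an ADME assay on microsomes from liver (Mus musculus) for metabolic stability, read by LC-MS, with NADPH named in the record, with a stated time of 60 min, tested at 1 uM, in the absence of a further agent (on this read-out lower numbers stand for a less stable compound and higher numbers for a more stable compound), only two compounds have been read so far. Compound 1 `COc1ccc(-n2c(C)nc3c(N4CC[C@@H](NC(C)=O)C4)nc(C)nc32)cc1OC` gives > 95%, which is a limit and not a number. Compound 2 `COc1ccc(-c2c(C)nc3c(N4CC[C@@H](NC(=O)c5ccccc5)C4)cc(C)nn23)cc1OC` gives > 95%, which is likewise a limit and not a number. The record so far therefore comes down to the limit of > 95% in this assay, at which 2 of the 2 values shown sit, and the position of compound 2 is known only as a limit.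

Compound 3 `COc1ccc(-c2c(C)nc3c(N4CC[C@@H](NC(=O)NC(C)C)C4)cc(C)nn23)cc1OC` keeps the core of compound 2 but carries isopropylamino in place of phenyl on a carbonyl carbon. The same difference can be read as benzamido to (isopropylcarbamoyl)amino. Within the data shown here, no measured pair of compounds shows what a change of this kind does in this assay, so its size is a matter of judgement.

Compound 2 holds the limit of > 95%, so the expectation can point only downward or to no change. The expected step is a number at least 5 percentage points lower from compound 2 to compound 3 (that floor lies within the scatter), a small one that may stay within the usual scatter. For compound 3 the estimated value is 90%, with an expected range from 70% to 99%.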

Compound 3, percent of the compound remaining: > 95%
Compound 3: only a limit was reported (the forecaster's own chance of this, stated with the estimate: 40%); middle value at least 5 percentage points from the limit.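

In this assay compound 3 gives > 95%, which is a limit and not a number. No step can be read between compound 2 and compound 3. The compounds shown leave open what isopropylamino in place of phenyl on a carbonyl carbon does in this assay, and how far each compound lies past the shared limit: the limit of > 95% in this assay, at which 3 of the 3 values shown sit.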